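The compounds below may be only part of what the source reports. "The series", "measured", "known", "first", "only" and "open" are said of these compounds alone.

In a functional assay on Huh-5-2 cells (Homo sapiens), read by MTT assay (a higher number here means that more compound is tolerated, a lower number that less compound is tolerated), three compounds sharing one core have been measured. Compound 1 (`O=C(O)c1ccc2c(c1)nc(-c1ccc(OCc3ccccc3-c3ccc(Cl)cc3)cc1)n2C1CCCCC1`) gives 25000 nM, compound 2 (`CN(C)S(=O)(=O)c1ccc(-c2ccc(Cl)cc2)c(COc2ccc(-c3nc4cc(C(=O)O)ccc4n3C3CCCCC3)cc2)c1`) gives 26000 nM, and compound 3 (`CN(C)C(=O)c1ccc(-c2ccc(Cl)cc2)c(COc2ccc(-c3nc4cc(C(=O)O)ccc4n3C3CCCCC3)cc2)c1`) gives 28000 nM. Compound 3 therefore stands level with the other two, and the steps that reach it show this: a 1.1-fold higher number from compound 1 to compound 3 (0.05 log units; within the scatter), and a 1.1-fold higher number from compound 2 to compound 3 (0.03 log units; within the scatter).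

Compound 4 (`O=C(O)c1ccc2c(c1)nc(-c1ccc(OCc3cc(C(=O)NCc4ccccc4)ccc3-c3ccc(Cl)cc3)cc1)n2C1CCCCC1`) departs from compound 3 at a single place, with benzylamino in place of dimethylamino on a carbonyl carbon. Going by the values given here, no measured pair makes this exchange, and none brings in a new ring at this place, so the evidence is indirect. The closest guides are the steps already given for compound 3, together with the dimethylsulfamoyl step, a 1.0-fold higher number from compound 1 to compound 2 (0.02 log units; within the scatter). All of these stayed within the scatter, so this assay has not yet separated any of the substituents tried on this aromatic carbon.

On that basis, no step beyond the scatter and no particular direction is expected, and the estimated change is a 1.1-fold lower number from compound 3 to compound 4 (0.05 log units; within the scatter). Compound 4 is expected to give about 25000 nM, with an estimated range from 13000 nM to 50000 nM.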

Compound 4, half-maximal cytotoxic concentration: 22000 nM
Compound 4: the middle estimate sits 1.1-fold (0.06 log units) above what was measured, within the range that was stated.
By their numbers in this assay, from the lowest: compounds 4, 1, 2 and 3 (each within the scatter of the next).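

Going by these compounds alone, compound 4 is the first here to carry a ring on this carbonyl carbon: benzylamino, with its six-membered aromatic ring of carbon only and one hydrogen-bond donor, takes the place of dimethylamino, and in this assay this exchange gives a 1.3-fold lower number from compound 3 to compound 4 (0.10 log units; within the scatter) without separating the two compounds. The other comparisons agree, with a 1.2-fold lower number from compound 2 to compound 4 (0.07 log units; within the scatter) where benzylcarbamoyl replaces dimethylsulfamoyl and a 1.1-fold lower number from compound 1 to compound 4 (0.06 log units; within the scatter) where it replaces hydrogen on the aromatic carbon, so this position now accepts a group bearing a ring with no step beyond the scatter, and all four compounds stand level. Nothing in the available data speaks to the reason for this flat result.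

On these data alone, it remains open whether any group at this aromatic carbon can move the number in this assay beyond the scatter in either direction, for example a simple amine, a carboxylic acid or a longer chain on the carbonyl carbon. Also open, as far as these compounds go, is whether a substituted benzyl group would behave as benzylamino does, or whether the level numbers would hold once the shared core itself is changed.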